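The compounds below may be only part of what the source reports. "The series", "measured", "known", "first", "only" and "open" are said of these compounds alone.

Among the compounds with values here, in a functional assay on K562 cells (Homo sapiens) for cytotoxicity, read by sulforhodamine B assay, with a stated time of 48 h (on this read-out lower numbers stand for stronger inhibition and higher numbers for weaker inhibition), compound 1 (`CCN(CC)CCCn1c(=O)/c(=C/c2cc(OC)c(OC)c(OC)c2)s/c1=C1/C(=O)Nc2ccc(C)cc21`) gives 4170 nM, the higher of the two numbers measured so far. Compound 2 (`CCN(CC)CCCn1c(=O)/c(=C/c2cc(OC)c(OC)c(OC)c2)s/c1=C1/C(=O)Nc2ccc(Cl)cc21`) gives 820 nM, with chloro in place of methyl on an aromatic carbon. That change is a 5.1-fold lower number from compound 1 to compound 2 (0.71 log units; beyond the scatter).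

Compound 3 (`CCN(CC)CCCn1c(=O)/c(=C/c2ccccc2O)s/c1=C1/C(=O)Nc2ccc(C)cc21`) keeps the methyl of compound 1 but carries 2-hydroxyphenyl in place of 3,4,5-trimethoxyphenyl on a double-bonded chain carbon bound to an aromatic carbon. Within the data shown here, no measured step touches this place, so the data give no direct guide to the direction of the change. Among the measured compounds shown here, the only measured step, a 5.1-fold lower number from compound 1 to compound 2 (0.71 log units; beyond the scatter), lies elsewhere in the molecule and bears on this question only indirectly, as a measure of how far one change has moved a number in this small set. A shift of about that size or smaller is therefore expected in this assay, with only a weak lean toward a lower number. The expected change is a 1.5-fold lower number from compound 1 to compound 3 (0.17 log units; within the scatter). For compound 3 the estimated value is 2800 nM, with an expected range from 800 nM to 10000 nM.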

Compound 3, half-maximal inhibitory concentration: 14800 nM
For compound 3 the middle estimate is 5.3-fold (0.72 log units) below the measured one, outside the stated range (above it).
By their numbers in this assay, from the lowest: compound 2; then compound 1; then compound 3.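

In this assay, the place on the double-bonded chain carbon bound to an aromatic carbon proves able to move the number: a 3.5-fold higher number from compound 1 to compound 3 (0.55 log units; beyond the scatter), with 2-hydroxyphenyl in place of 3,4,5-trimethoxyphenyl. This step runs in the opposite direction to the only earlier one, a 5.1-fold lower number from compound 1 to compound 2 (0.71 log units; beyond the scatter), and it shows that the aryl group can change the result while the methyl stays in place. The exchange replaces 12 heavy atoms, with no hydrogen-bond donor and 3 hydrogen-bond acceptors, by 7 heavy atoms, with 1 donor and 1 acceptor, and no accompanying measurement bears on why the number rose.

With so many counted features changing in one step, the compounds shown do not separate the gain of the hydroxyl from the loss of the methoxy groups, and a plain phenyl or a 2-methoxyphenyl group at this place would be needed to tell them apart. As far as these compounds go, it also remains open whether chloro in place of methyl would lower the number to a similar extent when 2-hydroxyphenyl is present.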